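This account rests on a few compounds, and the source may have more. Where it says the series, first, only, none or still open, it means among the compounds named here.

In a functional assay on MCF7 cells (Homo sapiens) for inhibition (a higher number here means a weaker inhibitor, a lower number a stronger inhibitor), compound 1 (`O=C(CC(CC(=O)NC1Cc2ccccc2C1)c1ccc(Cl)cc1)NCCN1CCCCC1`) reads 35500 nM as its half-maximal inhibitory concentration. Compound 2 (`CCN(CC)CCNC(=O)CC(CC(=O)NC1Cc2ccccc2C1)c1ccc(Cl)cc1`) reads 75000 nM on the same measure, the higher of the two actual numbers. Between these two lies a 2.1-fold higher number from compound 1 to compound 2 (0.32 log units; beyond the scatter), a modest step on the diethylamino side. Compound 3 (`CCN(CC)CCNC(=O)CC(CC(=O)NC1Cc2ccccc2C1)c1ccccc1`) gives > 100000 nM as a limit of the assay and not a number. The loss of chloro gives an at least 1.3-fold higher number from compound 2 to compound 3 (0.12 log units; that floor lies within the scatter) in that comparison.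

Compound 4 (`CCN(CC)CCNC(=O)CC(CC(=O)N(C)C1Cc2ccccc2C1)c1ccc(Cl)cc1`) differs by methyl in place of hydrogen on an amide-type nitrogen, which is methyl in place of hydrogen on an amide-type nitrogen. For the measured compounds named here, neither measured step touches that nitrogen, so they bear on it only indirectly, and they offer no direct precedent for this change. Both are small, so no step beyond the scatter is expected in this assay, with any drift more likely towards a higher number. The expected change is a 1.1-fold higher number from compound 2 to compound 4 (0.03 log units; within the scatter) on this estimate. Compound 4 is estimated at 80000 nM as the middle value. The expected range for compound 4 runs from 35000 nM to 100000 nM in this measure.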

Compound 4, half-maximal inhibitory concentration: 28800 nM
The estimate for compound 4 lay 2.8-fold (0.44 log units) above the measured number; the measured number lies below the stated range.
By their numbers in this assay, from the lowest: compounds 4 and 1 (each within the scatter of the next); then compound 2. At a limit, above all of these: compound 3.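

In this assay, methyl in place of hydrogen on the amide-type nitrogen gives a 2.6-fold lower number from compound 2 to compound 4 (0.42 log units; beyond the scatter), so the number can move beyond the scatter through a change at this nitrogen, whose other neighbours are the carbonyl carbon and a saturated ring carbon. The earlier steps shown here changed only the diethylamino and piperidin-1-yl groups and the chloro, and they said nothing about the amide hydrogen.

Going by these compounds, it remains open whether ethyl or benzyl on this nitrogen would carry the change further, and whether methyl here combined with piperidin-1-yl in one compound would add to it. Whether methyl acts the same way without the chloro cannot be judged from compound 3, whose value is a limit and not a number: the limit of > 100000 nM in this assay, at which 1 of the 4 values shown sits.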